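Changing the Sulfonamide Ring of Compound 3

The source may hold more compounds than are shown below. What is called first, only, known or untested is meant among the compounds shown, and "the series" means these compounds.

In a physicochemical assay for solubility (on this read-out higher numbers stand for higher solubility and lower numbers for lower solubility), compound 1 (`O=S(=O)(Nc1nccs1)c1ccc2c(c1)OCC[C@H]2c1ccc(C(F)(F)F)cc1-n1ccnn1`) gives 154000 nM, compound 2 (`Cc1nc(-c2cc(C(F)(F)F)ccc2[C@H]2CCOc3cc(S(=O)(=O)Nc4ncc(F)cn4)ccc32)co1`) gives 281000 nM and compound 3 (`Cc1ccc(-c2cc(C(F)(F)F)ccc2[C@H]2CCOc3cc(S(=O)(=O)Nc4ncc(F)cn4)ccc32)cn1`) gives 225000 nM. Compound 3 therefore lies within the usual scatter of both compound 1 and compound 2. Compound 4 (`Cc1ccc(-c2cc(C(F)(F)F)ccc2[C@H]2CCOc3cc(S(=O)(=O)Nc4ccncn4)ccc32)cn1`) differs from compound 3 in one place: pyrimidin-4-yl in place of 5-fluoropyrimidin-2-yl on a sulfonamide nitrogen. In short, pyrimidin-4-yl stands in place of 5-fluoropyrimidin-2-yl on a sulfonamide nitrogen. Within the data shown here, the only measured step, a 1.2-fold lower number from compound 2 to compound 3 (0.10 log units; within the scatter), changes a group on an aromatic carbon instead, so it offers only indirect guidance. Among the measured compounds shown here, with no measured step at the sulfonamide nitrogen, no shift beyond the scatter is expected, and the estimate is a 1.1-fold lower number from compound 3 to compound 4 (0.05 log units; within the scatter). For compound 4 the expected value is 200000 nM, with an estimated range of 90000 nM to 420000 nM.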

Compound 4, solubility: 181000 nM
Compound 4: the middle estimate sits 1.1-fold (0.04 log units) above what was measured; the measured number falls inside the stated range.
By their numbers in this assay, from the lowest: compounds 1, 4, 3 and 2 (each within the scatter of the next).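

Putting pyrimidin-4-yl in place of 5-fluoropyrimidin-2-yl on the sulfonamide nitrogen gives a 1.2-fold lower number from compound 3 to compound 4 (0.09 log units; within the scatter) in this assay, and this is the only step shown at this position. On this read-out, these two rings cannot be told apart here. Nothing available explains this result.

On these data alone, it remains open whether the same swap reads alike with the 2-methyl-1,3-oxazol-4-yl group of compound 2 in place of the 6-methylpyridin-3-yl group. As far as these compounds go, it also remains open how a pyrimidine ring carrying an amine or a carboxylic acid would read on this nitrogen.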